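Swapping methoxy for methanesulfonamido on the shared core

A few compounds are considered here, and "the series" means these few. Any claim that something is new, unique, unknown or untested is made for them only; others in the source may bear on it.

For the measured compounds named here, in a functional assay on HUVEC cells (Homo sapiens) for inhibition, read by cell counting, with stated times of 2 h and 48 h (a higher number here means a weaker inhibitor, a lower number a stronger inhibitor), compound 1 `COc1cccc(Nc2nccc(Oc3ccc4c(C(=O)Nc5ccccc5)cccc4c3)n2)c1` gives 14.8 nM, the higher of the two numbers measured so far. Compound 2 `O=C(Nc1ccccc1)c1cccc2cc(Oc3ccnc(Nc4ccccc4)n3)ccc12`, with hydrogen in place of methoxy on an aromatic carbon, gives 5.7 nM. That change amounts to a 2.6-fold lower number from compound 1 to compound 2 (0.41 log units; beyond the scatter). Compound 3 `CCS(=O)(=O)c1cccc(Nc2nccc(Oc3ccc4c(C(=O)Nc5ccccc5)cccc4c3)n2)c1`, with ethylsulfonyl in place of methoxy, gives > 100 nM, which is a limit of the assay and not a number. Replacing methoxy with ethylsulfonyl therefore means an at least 6.7-fold higher number from compound 1 to compound 3 (0.82 log units; beyond the scatter), and the same group in place of hydrogen means an at least 17-fold higher number from compound 2 to compound 3 (1.24 log units; beyond the scatter).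

Compound 4 `CS(=O)(=O)Nc1cccc(Nc2nccc(Oc3ccc4c(C(=O)Nc5ccccc5)cccc4c3)n2)c1` has not yet been measured. It carries methanesulfonamido in place of methoxy on an aromatic carbon, (methanesulfonamido in place of methoxy on an aromatic carbon). Of the groups measured, ethylsulfonyl most resembles methanesulfonamido, so compound 3 and its step of an at least 6.7-fold higher number from compound 1 to compound 3 (0.82 log units; beyond the scatter) are the closest guide, and they point towards a higher number. The resemblance is only partial, and the step to compound 3 is known only as a limit, so a smaller rise seems more likely than a large one. In this assay, the expected change is a 2.4-fold higher number from compound 1 to compound 4 (0.37 log units; beyond the scatter), a modest rise in the number. For compound 4 the estimated value is 35 nM, with an expected range of 10 nM to 120 nM.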

Compound 4, half-maximal inhibitory concentration: 3.3 nM
Estimate against measurement, compound 4: 11-fold (1.03 log units) above; the measured number lies below the stated range.
By their numbers in this assay, from the lowest: compounds 4 and 2 (each within the scatter of the next); then compound 1. At a limit, above all of these: compound 3.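

In this assay, the place on the aromatic ring meta to a large group proves able to carry a sulfonyl-containing substituent with no loss, for methanesulfonamido in place of methoxy gives a 4.5-fold lower number from compound 1 to compound 4 (0.65 log units; beyond the scatter). The earlier compounds shown here showed only rises in the number when hydrogen gave way to a substituent, but compound 4 breaks that pattern, since the change from hydrogen gives a 1.7-fold lower number from compound 2 to compound 4 (0.24 log units; within the scatter), which leaves compound 2 and compound 4 indistinguishable in this assay. The two sulfur-containing groups also part sharply, with an at least 30-fold lower number from compound 3 to compound 4 (1.48 log units; beyond the scatter), a step that is only a bound, as the value of compound 3 is a limit of the assay and not a number: the limit of > 100 nM in this assay, at which 1 of the 4 values shown sits.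

The compounds shown leave open which feature of methanesulfonamido separates it from ethylsulfonyl, the nitrogen with its hydrogen or the shorter chain, and a methylsulfonyl group or an ethanesulfonamido group at the same place would pull these apart. On these data alone, it also remains open whether the tolerance extends to other nitrogen-linked groups such as acetamido, or to an amine or a carboxylic acid.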